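A few compounds are considered here, and "the series" means these few. Any claim that something is new, unique, unknown or untested is made for them only; others in the source may bear on it.

Measured in an assay on membranes from HeLa cells for displacement of a labelled ligand from adenosine receptor A3 (Homo sapiens), read by scintillation counting, with a stated time of 180 min, tested at 1 uM; on this read-out higher numbers stand for more inhibition at the one concentration tested (going by the name of the read-out) and lower numbers for less inhibition:

compound 1 `CC1=C(C(=O)OC(C)(C)C)C(c2cccs2)NC(=O)N1` gives 7%
compound 2 `CC1=C(C(=O)OCc2ccccc2)C(c2cccs2)NC(=O)N1` gives 8%
compound 3 `CC1=C(C(=O)OC(C)(C)C)C(c2ccoc2)NC(=S)N1` gives 19%

Compound 1 and compound 2 share a core and differ in one place: benzyl in place of tert-butyl on an oxygen next to a carbonyl group. The step this made, a number 1 percentage points higher from compound 1 to compound 2 (within the scatter), is within the scatter, so the two values cannot be ordered. Compound 3 has the same atoms as compound 1 joined differently; the difference between the two cores is not broken down here. Compound 3 stands highest of the three values, and its steps to both compound 2 and compound 1 are beyond the scatter.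

Compound 4 `CC1=C(C(=O)OCc2ccccc2)C(c2ccoc2)NC(=S)N1` is not yet measured. It is made from compound 3 by the same change seen from compound 1 to compound 2: benzyl in place of tert-butyl on an oxygen next to a carbonyl group. The place is the same word for word in both pairs. For the measured compounds named here, the only guide for the size of the step is the earlier pair, and that step was within the scatter.

In this assay the step from compound 3 to compound 4 is expected to be about a number 1 percentage points higher from compound 3 to compound 4 (within the scatter), because the same change gave a number 1 percentage points higher from compound 1 to compound 2 (within the scatter). Compound 4 is therefore estimated at 20%, with a range from 10% to 32%.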

Compound 4, a percentage reported as inhibition, at one concentration (the size of the read-out at that concentration, not a potency): 20%
Compound 4: the middle estimate sits on the measured number at the digits printed; the range from low to high includes it.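

In this assay, benzyl in place of tert-butyl on an oxygen next to a carbonyl group gives a number 1 percentage points higher from compound 3 to compound 4 (within the scatter), and this step matches the one on the other core: the same change on two cores in this assay, a number 1 percentage points higher (within the scatter) from compound 1 to compound 2 and a number 1 percentage points higher (within the scatter) from compound 3 to compound 4, 0 percentage points apart, within the scatter of two such steps. On these two cores, the change therefore carries over as a step that stays within the scatter, and the core of compound 1 and the core of compound 3 give the same reading of it. For the compounds shown here, this does not show that benzyl and tert-butyl are interchangeable in general: only two cores are covered, a step within the scatter cannot be ordered, and a reading at one concentration is not a potency.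

Still open, going by these compounds, is whether a different group on that oxygen, such as a longer chain or a chain ending in an amine, would give a step beyond the scatter. Also open, on these data alone, is whether a carboxylic acid in place of the ester would do so on either core.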